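The compounds below may be only part of what the source reports. "The series", "measured", "known", "first", "only" and "open" are said of these compounds alone.

Of the compounds shown here, three of the shared core have been measured in a functional assay on MCF7 cells (Homo sapiens) for antiproliferative activity, read by MTT assay, with a stated time of 72 h; a higher number here means a weaker inhibitor, a lower number a stronger inhibitor. Compound 1 `Cc1cc(NCCN2CCN(C)CC2)nc2ccc(NC(=O)c3ccc(Cl)c(Cl)c3)cc12` gives 1700 nM, compound 2 `Cc1cc(N2CCCCC2)nc2ccc(NC(=O)c3ccc(Cl)c(Cl)c3)cc12` gives 31100 nM, and compound 3 `CCN1CCN(c2cc(C)c3cc(NC(=O)c4ccc(Cl)c(Cl)c4)ccc3n2)CC1` gives 1380 nM, the lowest number of the three, within the scatter of compound 1 and well apart from compound 2. Compound 4 `CCN(CC)c1cc(C)c2cc(NC(=O)c3ccc(Cl)c(Cl)c3)ccc2n1` differs from compound 3 by diethylamino in place of 4-ethylpiperazin-1-yl on an aromatic carbon. The step that bears on this is a 23-fold lower number from compound 2 to compound 3 (1.35 log units; beyond the scatter), where a ring with a single nitrogen and one acceptor was replaced by the 4-ethylpiperazin-1-yl group. Compound 4 again carries a group with one nitrogen and one acceptor, so a large rise is expected, roughly reversing that step. Compound 4 is therefore estimated at 20000 nM (range 5000 nM to 60000 nM), an expected step of a 14-fold higher number from compound 3 to compound 4 (1.16 log units; beyond the scatter).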

Compound 4, half-maximal inhibitory concentration: > 50000 nM
Compound 4 gave a limit, no number; the forecaster's own chance of this, stated with the estimate: 10%; middle value at least 2.5-fold (0.39 log units) from the limit.
By their numbers in this assay, from the lowest: compounds 3 and 1 (each within the scatter of the next); then compound 2. At a limit, above all of these: compound 4.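

In this assay compound 4 gives > 50000 nM, which is a limit and not a number. At this position next to the ring nitrogen, the open-chain diethylamino group gives an at least 36-fold higher number from compound 3 to compound 4 (1.55 log units; beyond the scatter) and an at least 29-fold higher number from compound 1 to compound 4 (1.46 log units; beyond the scatter), so among the four compounds only the two carrying a piperazine, compounds 1 and 3, have low numbers, and none goes against this. The comparison with the piperidin-1-yl group gives an at least 1.6-fold higher number from compound 2 to compound 4 (0.20 log units; that floor lies within the scatter), which sets no order between those two. Still open, as far as these compounds go, is whether a morpholin-4-yl group, with oxygen in place of the second ring nitrogen, would stay with compounds 1 and 3 or fall with compounds 2 and 4.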